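A few compounds are considered here, and "the series" means these few. Any claim that something is new, unique, unknown or untested is made for them only; others in the source may bear on it.

In a functional assay on A549 cells (Homo sapiens) for cytotoxicity, read by MTT assay, with a stated time of 48 h (on this read-out lower numbers stand for stronger inhibition and higher numbers for weaker inhibition), compound 1 `COc1ccc(C2=NOC(COc3ccc(-c4nnnn4-c4cc(OC)c(OC)c(OC)c4)cc3N)C2)cc1[N+](=O)[O-]` gives 2220 nM on the shared core. Compound 2 `COc1cc(-n2nnnc2-c2ccc(OCC3CC(c4ccc(C(F)(F)F)cc4)=NO3)c(N)c2)cc(OC)c1OC` gives 1220 nM in this assay as well. The step of a 1.8-fold lower number from compound 1 to compound 2 (0.26 log units; within the scatter) came with 4-(trifluoromethyl)phenyl in place of 4-methoxy-3-nitrophenyl on a carbon with a double bond to nitrogen, so compound 2 stands level with compound 1 on these numbers. Compound 3 `COc1cc(-n2nnnc2-c2ccc(OCC3CC(c4ccc(OC)c(OC)c4OC)=NO3)c(N)c2)cc(OC)c1OC` changes that same carbon again, with 2,3,4-trimethoxyphenyl in place of 4-(trifluoromethyl)phenyl, a difference that counts out as 2,3,4-trimethoxyphenyl in place of 4-(trifluoromethyl)phenyl on a carbon with a double bond to nitrogen and leaves the rest of compound 2 untouched. Among the measured compounds shown here, only one measured step bears on this place, and the step of a 1.8-fold lower number from compound 1 to compound 2 (0.26 log units; within the scatter) stayed small, so no shift beyond the scatter is expected in this assay here. The estimated change is a 1.2-fold higher number from compound 2 to compound 3 (0.09 log units; within the scatter) and no more. Compound 3 is expected to give about 1500 nM with an estimated range from 500 nM to 4500 nM when it is measured.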

Compound 3, half-maximal inhibitory concentration: 2030 nM
Estimate against measurement, compound 3: 1.4-fold (0.13 log units) below; the measured number falls inside the stated range.
By their numbers in this assay, from the lowest: compounds 2, 3 and 1 (each within the scatter of the next).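

Across this assay, the place on the carbon with a double bond to nitrogen has now held a third substituted phenyl group without a shift beyond the scatter: a 1.7-fold higher number from compound 2 to compound 3 (0.22 log units; within the scatter), and a 1.1-fold lower number from compound 1 to compound 3 (0.04 log units; within the scatter). The step from compound 2 to compound 3 also replaces a group with 0 hydrogen-bond acceptors by one with 3, yet the values of these three compounds remain within the scatter of one another. No supporting measurement accounts for this flat response.

Going by these compounds, all three compounds carry a substituted phenyl ring at this place, so it remains open whether an amine or a carboxylic acid there would move the number beyond the scatter. On these data alone, the effect of changes elsewhere on the shared core also remains open.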